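The compounds below may be only part of what the source reports. "The series", "measured", "known", "first", "only" and "open" are said of these compounds alone.

Among the measured compounds shown here, compound 2, `COc1ccccc1N1CCN(CC(=O)Nc2ccc(C(=O)/C=C/c3cn(Cc4ccc(Br)cc4)nn3)cc2)CC1`, and compound 1, `CCCCCCCCn1cc(/C=C/C(=O)c2ccc(NC(=O)CN3CCN(C(=O)OC(C)(C)C)CC3)cc2)nn1`, are the two measured members. In a functional assay on SK-N-SH cells (Homo sapiens) for inhibition, read by MTT assay (on this read-out lower numbers stand for stronger inhibition and higher numbers for weaker inhibition), compound 2 gives 28000 nM; in this assay compound 1 gives 38000 nM. Compound 2 carries the lower of the two numbers, but the gap to compound 1 lies within the scatter, so the two values are taken as equivalent.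

Compound 3, `CCCCCCCCn1cc(/C=C/C(=O)c2ccc(NC(=O)CN3CCN(c4ccccc4OC)CC3)cc2)nn1`, has not been measured. Compared with compound 2 it shows (heptyl in place of 4-bromophenyl on a saturated chain carbon bound to an aromatic nitrogen). For the measured compounds named here, no measured pair in this set isolates that change, so its effect is unknown. Since compound 1, which already carries the octyl chain on the aromatic nitrogen, gives 38000 nM and sits within the scatter of compound 2, the expectation is a step of a 1.2-fold higher number from compound 2 to compound 3 (0.08 log units; within the scatter), no larger than the scatter and of no firm direction. Compound 3 is therefore estimated at 34000 nM, with a range from 12000 nM to 95000 nM.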

Compound 3, half-maximal inhibitory concentration: 21500 nM
Compound 3: the middle estimate sits 1.6-fold (0.20 log units) above what was measured; the range from low to high includes it.
By their numbers in this assay, from the lowest: compounds 3, 2 and 1 (each within the scatter of the next).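

In this assay, exchanging 4-bromobenzyl for octyl on the aromatic nitrogen gives a 1.3-fold lower number from compound 2 to compound 3 (0.11 log units; within the scatter), so at this place a chain and a ring-bearing group with the same count of heavy atoms are not told apart. On the amine nitrogen in a ring, 2-methoxyphenyl in place of tert-butoxycarbonyl gives a 1.8-fold lower number from compound 1 to compound 3 (0.25 log units; within the scatter), so neither place has yet shown a step that stands clear of the scatter. No measurement at hand explains either step.

The compounds shown leave open whether any group at these two places can move the number beyond the scatter. A shorter chain or a chain ending in a carboxylic acid on the aromatic nitrogen, or a pyridine on the amine nitrogen in a ring, would put that to the test.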